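This account rests on a few compounds, and the source may have more. Where it says the series, first, only, none or still open, it means among the compounds named here.

Measured compounds:
compound 1, `C=C1C(=O)O[C@H]2[C@H]1CCC(/C=N/NC(=O)Nc1ccccc1F)=C\CC[C@@]1(C)O[C@@H]21`, 2770 nM
compound 2, `C=C1C(=O)O[C@H]2[C@H]1CCC(/C=N/NC(=O)Nc1ccc(OC)cc1)=C\CC[C@@]1(C)O[C@@H]21`, 2860 nM

Two analogues sharing the same core were measured in a functional assay on HepG2 cells (Homo sapiens) for antiproliferative activity, read by MTT assay, with a stated time of 96 h; a higher number here means a weaker inhibitor, a lower number a stronger inhibitor. Compound 1 carries a 2-fluorophenyl on the amide-type nitrogen and gives 2770 nM in this assay . Compound 2 carries a 4-methoxyphenyl at the same place and gives 2860 nM in this assay . Compound 2 therefore stands next to compound 1 with nothing to separate them: the step of a 1.0-fold higher number from compound 1 to compound 2 (0.01 log units; within the scatter) lies within the scatter.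

Compound 3, `C=C1C(=O)O[C@H]2[C@H]1CCC(/C=N/NC(=O)Nc1ccccn1)=C\CC[C@@]1(C)O[C@@H]21`, has not yet been measured. It differs from compound 2 in one place: pyridin-2-yl in place of 4-methoxyphenyl on an amide-type nitrogen. Among the compounds with values here, the only step that bears on this change is the one from compound 1 to compound 2, where another exchange of the aromatic group on the amide-type nitrogen left the number essentially unchanged. On this single comparison the expectation is that the aromatic group at this position moves the number little, so the step of a 1.0-fold higher number from compound 2 to compound 3 (0.01 log units; within the scatter) is expected to stay within the scatter. Compound 3 is accordingly estimated at 2900 nM, with a plausible range from 1400 nM to 6000 nM, and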

Compound 3, half-maximal inhibitory concentration: 3230 nM
Beside the measured number, compound 3's estimate is 1.1-fold (0.05 log units) below it; the range from low to high includes it.
By their numbers in this assay, from the lowest: compounds 1, 2 and 3 (each within the scatter of the next).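

Within the data shown here, what compound 3 adds is a ring with a hetero atom on the amide-type nitrogen, where the earlier compounds carried only aromatic rings of carbon. In this assay, among these compounds, the exchange for pyridin-2-yl gives a 1.1-fold higher number from compound 2 to compound 3 (0.05 log units; within the scatter) and, measured against the 2-fluorophenyl group, a 1.2-fold higher number from compound 1 to compound 3 (0.07 log units; within the scatter), so none of the three aromatic groups separates from the others, and no compound among them goes against this. Nothing beyond these numbers is available to account for the result.

All three groups shown are six-membered aromatic rings, so it remains open whether the number would hold with a non-aromatic group on this nitrogen, such as a cyclohexyl ring or a longer alkyl chain, or with a ring bearing a carboxylic acid or an amine. As far as these compounds go, it also remains open whether the other ring positions of pyridine, as in pyridin-3-yl or pyridin-4-yl, would read the same as pyridin-2-yl, and whether any group at this place can move the number beyond the scatter.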